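Hydrazone series: hydroxy for tert-butyl on the benzoyl ring

A few compounds are considered here, and "the series" means these few. Any claim that something is new, unique, unknown or untested is made for them only; others in the source may bear on it.

Measured so far:
- compound 1 `COc1cc(/C=C/C=N/NC(=O)c2ccc(C(C)(C)C)cc2)ccc1O` gives 76.1%
- compound 2 `O=C(N/N=C/c1ccc(O)cc1)c1ccc(O)cc1` gives 65%
- compound 3 `COc1ccc(/C=C/C=N/NC(=O)c2ccc(C(C)(C)C)cc2)cc1` gives 7.1%

In a physicochemical assay, read by spectrophotometry, with a stated time of 60 min, tested at 1000 uM (a higher number here means a stronger effect of the compound at the concentration tested, a lower number a weaker effect), compound 3 stands lowest of the three numbers, beyond the scatter below compound 2 and further still below compound 1. Compound 4 `COc1ccc(/C=C/C=N/NC(=O)c2ccc(O)cc2)cc1` has not been measured. It differs from compound 3 in one place: hydroxy in place of tert-butyl on an aromatic carbon.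

The step from compound 3 to compound 4 is expected to be an increase beyond the scatter, a number 37.9 percentage points higher from compound 3 to compound 4 (beyond the scatter), because compound 2, which carries hydroxy on both ends, gives 65% and compound 3 gives 7.1%. For compound 4 the estimate is 45%, with a range from 20% to 70%.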

Compound 4, a percentage reported as inhibition, at one concentration (the size of the read-out at that concentration, not a potency): 2.8%
For compound 4 the middle estimate is 42.2 percentage points above the measured one; measured number outside the range, below it.
By their numbers in this assay, from the lowest: compounds 4 and 3 (each within the scatter of the next); then compound 2; then compound 1.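

In this assay hydroxy in place of tert-butyl on an aromatic carbon, para to a large group, gives a number 4.3 percentage points lower from compound 3 to compound 4 (within the scatter) and so does not separate the two groups. On the core of compound 3, a hydroxy at this position is therefore not enough on its own to lift the read-out, although the groups differ in heavy atoms and hydrogen-bond donors. Nothing available bears on why the two groups read alike.

As far as these compounds go, whether an amine or a carboxylic acid at this position would read differently stays open. So does whether the same change would read alike on the core of compound 1.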